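Replacing the propanoyl ethyl of compound 1 with an oxazole ring

The compounds below may be only part of what the source reports. "The series", "measured", "known", "first", "only" and "open" are said of these compounds alone.

Compound 1 `CCC(=O)Nc1c(C(O)(C(F)(F)F)C(F)(F)F)ccc2ccccc12` is the reference here. In a functional assay (Sus scrofa) with sulfonylurea receptors; K-ATP channels (Homo sapiens) as the target (a lower number here means that less compound is needed, a higher number that more compound is needed for the effect), compound 1 gives 8.91 nM, the lowest number among the three measured compounds. Compound 2 `O=C(Nc1c(C(O)(C(F)(F)F)C(F)(F)F)ccc2ccccc12)C1CC1`, which carries a cyclopropyl in place of the ethyl on the carbonyl carbon, gives 126 nM, and compound 3 `N#Cc1cccc(C(=O)Nc2c(C(O)(C(F)(F)F)C(F)(F)F)ccc3ccccc23)c1`, with a 3-cyanophenyl at that carbonyl carbon, gives 372 nM.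

Compound 4 `O=C(Nc1c(C(O)(C(F)(F)F)C(F)(F)F)ccc2ccccc12)c1cnco1` has not yet been measured. Its difference from compound 1 is 1,3-oxazol-5-yl in place of ethyl on a carbonyl carbon.

Among the compounds with values here, two measured steps bear on this change. Both leave the ethyl on the carbonyl carbon and both moved the number upward: a 14-fold higher number from compound 1 to compound 2 (1.15 log units; beyond the scatter), and the larger 42-fold higher number from compound 1 to compound 3 (1.62 log units; beyond the scatter). Between the two larger groups, a 3.0-fold higher number from compound 2 to compound 3 (0.47 log units; beyond the scatter). The 1,3-oxazol-5-yl is a five-membered aromatic ring with 2 hetero atoms, a ring like the cyclopropyl and aromatic like the 3-cyanophenyl, so a step higher, beyond the scatter, is expected for compound 4, somewhere between those two measured steps. The expected step is a 22-fold higher number from compound 1 to compound 4 (1.35 log units; beyond the scatter). Compound 4 is therefore estimated to give 200 nM in this assay, with a range from 50 nM to 800 nM.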

Compound 4, half-maximal effective concentration: 302 nM
Compound 4: middle estimate off by 1.5-fold (0.18 log units), on the low side; the range from low to high includes it.
By their numbers in this assay, from the lowest: compound 1; then compound 2; then compounds 4 and 3 (each within the scatter of the next).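

In this assay, the 1,3-oxazol-5-yl at the carbonyl carbon gives a large loss against the ethyl, a 34-fold higher number from compound 1 to compound 4 (1.53 log units; beyond the scatter), so a second aromatic ring, this one with hetero atoms and hydrogen-bond acceptors, also sits far from compound 1. Exchanging the 3-cyanophenyl for the 1,3-oxazol-5-yl makes no difference that can be read, a 1.2-fold lower number from compound 3 to compound 4 (0.09 log units; within the scatter), whereas the cyclopropyl stays modestly apart, a 2.4-fold higher number from compound 2 to compound 4 (0.38 log units; beyond the scatter), so the two aromatic rings group together on the high side of the cyclopropyl, and across these four compounds the ethyl remains alone at the low end. No data shown here account for this grouping or for the gap to the ethyl.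

The compounds shown leave open whether the position favours short open chains in general, since a methyl or a longer chain such as propyl would show if the low number belongs to the ethyl alone or extends to its neighbours. They also leave open whether the aromatic character matters or simply the presence of a larger ring, a question that a saturated ring such as tetrahydrofuranyl or cyclopentyl at the same carbonyl carbon could address.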